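One Small Group for Another on the Aryl Ring

A few compounds are considered here, and "the series" means these few. Any claim that something is new, unique, unknown or untested is made for them only; others in the source may bear on it.

All three measured compounds were tested in a functional assay on BGC-823 cells (Homo sapiens) for inhibition, read by CCK-8 assay, with a stated time of 48 h; on this read-out higher numbers stand for weaker inhibition and lower numbers for stronger inhibition.

Compound 1 `O=C1CSC(N2N=C(c3ccc(Br)cc3)CC2c2cccc3ccccc23)=N1` gives 14600 nM.
Compound 2 `O=C1CSC(N2N=C(c3ccc(Br)cc3)CC2c2ccc3ccccc3c2)=N1` gives 11700 nM.
Compound 3 `Cc1ccc(C2=NN(C3=NC(=O)CS3)C(c3cccc4ccccc34)C2)cc1` gives 10000 nM.

Compound 3 shows the lowest of the three numbers, but its gaps to compound 2 and to compound 1 both fall within the usual scatter of repeated measurements, so the three compounds cannot be told apart on these data. Going by the values given here, only one pair differs in a single place: from compound 1 to compound 3, a methyl replaces a bromo on an aromatic carbon, and that gave a 1.5-fold lower number from compound 1 to compound 3 (0.16 log units; within the scatter).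

Compound 4 `O=C1CSC(N2N=C(c3ccc(F)cc3)CC2c2cccc3ccccc23)=N1` differs from compound 3 by fluoro in place of methyl on an aromatic carbon. This is a swap of one small group for another at the very same aromatic carbon where the earlier swap of bromo for methyl left the number essentially unchanged. Among the compounds with values here, with only that one step to lean on, and with it lying within the scatter, no step beyond the scatter is expected here either; the expected step is a 1.1-fold higher number from compound 3 to compound 4 (0.04 log units; within the scatter).

Compound 4 is therefore estimated to give 11000 nM in this assay, with a range from 5000 nM to 25000 nM.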

Compound 4, half-maximal inhibitory concentration: 19300 nM
Estimate against measurement, compound 4: 1.8-fold (0.24 log units) below; the measured number falls inside the stated range.
By their numbers in this assay, from the lowest: compounds 3, 2, 1 and 4 (each within the scatter of the next).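

With compound 4, three groups (bromo, methyl and fluoro) can be compared at the same aromatic carbon, para to a large group, in this assay. Fluoro in place of methyl gives a 1.9-fold higher number from compound 3 to compound 4 (0.29 log units; within the scatter) and fluoro in place of bromo gives a 1.3-fold higher number from compound 1 to compound 4 (0.12 log units; within the scatter); together with the earlier step, this means that no swap among these three single-atom groups separates the compounds, so this small set shows no ranking of them at this carbon. No measurement is available here that could explain these steps.

Whether an amine, a carboxylic acid, a methoxy group or a longer chain at this carbon would give a step beyond the scatter remains open, since the three groups shown are all small and each adds only one heavy atom. Also open, on these data alone, is whether methyl or fluoro at this carbon would give similar numbers on the core of compound 2, which appears here only with bromo.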